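Compound 3 and its unmeasured rearranged partner, compound 4

This account rests on a few compounds, and the source may have more. Where it says the series, first, only, none or still open, it means among the compounds named here.

Measured in a functional assay on HCT-116 cells (Homo sapiens) for cytotoxicity, read by MTT assay; on this read-out higher numbers stand for weaker inhibition and lower numbers for stronger inhibition:
- compound 1 `Nc1ccccc1NC(=O)c1ccc(CSc2ccccn2)cc1`: 1000 nM
- compound 2 `Nc1ccccc1NC(=O)c1ccc(CNc2cccc(F)n2)cc1`: 1000 nM
- compound 3 `COc1cccc(NCc2ccc(C(=O)Nc3ccccc3N)cc2)n1`: 800 nM

All three compounds lie within the scatter of one another, so compound 3 stands level with the other two and no order can be drawn among them.

Compound 4 `COc1ccc(NCc2ccc(C(=O)Nc3ccccc3N)cc2)cn1` has not yet been measured. It has the same atoms as compound 3, joined differently, with 6-methoxypyridin-3-yl in place of 6-methoxypyridin-2-yl on an amine nitrogen.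

Going by the values given here, two measured steps bear on this change, though only indirectly. Placing (6-fluoropyridin-2-yl)amino where (pyridin-2-yl)sulfanyl stood gave no change at the digits printed from compound 1 to compound 2 (within the scatter). Placing methoxy where fluoro stood gave a 1.3-fold lower number from compound 2 to compound 3 (0.10 log units; within the scatter). Among the compounds with values here, both steps are small, but neither is the same swap as the one in compound 4, so the data hold no direct precedent for it.

On these two steps and on compound 3 at 800 nM, no change beyond the scatter is expected in this assay, and neither direction is favoured. The estimated step is no change at the digits printed from compound 3 to compound 4 (within the scatter). The expected value for compound 4 is 800 nM, within an estimated range of 300 nM to 2000 nM.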

Compound 4, half-maximal inhibitory concentration: 700 nM
For compound 4 the middle estimate is 1.1-fold (0.06 log units) above the measured one, and the stated range covers the measured number.
By their numbers in this assay, from the lowest: compounds 4, 3, 1 and 2 (each within the scatter of the next).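

In this assay, 6-methoxypyridin-3-yl in place of 6-methoxypyridin-2-yl on an amine nitrogen gives a 1.1-fold lower number from compound 3 to compound 4 (0.06 log units; within the scatter) and so the rearrangement of the ring leaves the read-out level. With 6-methoxypyridin-3-yl in place of 6-fluoropyridin-2-yl at the same place, the result is a 1.4-fold lower number from compound 2 to compound 4 (0.15 log units; within the scatter) and so even a swap that alters both the substituent and the ring's point of attachment does not move the number beyond the scatter. Going by these compounds alone, the earlier compounds carried only pyridin-2-yl groups, so this is the first sign that a pyridin-3-yl group on this amine nitrogen is accepted in this assay without a change that can be told from the scatter. Nothing available here offers a cause for this flat result.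

From the compounds shown here alone, whether the read-out would stay level with a pyridin-4-yl group or a plain phenyl ring on the amine nitrogen remains open, as does the effect of a carboxylic acid or a longer chain in place of methoxy. All four compounds also share the same core, so they cannot show whether changes elsewhere in the molecule would be met with the same indifference.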